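The source may report more compounds than this note shows. Statements on the series, on what has been measured and on what is new or still open speak of the compounds shown alone.

In an assay on C6 cells for antagonist activity at prostaglandin E2 receptor EP2 subtype (Homo sapiens), read by TR-FRET, with stated times of 10 min and 40 min, tested at 1 uM (a higher number here means a weaker inhibitor, a lower number a stronger inhibitor), three compounds have been measured so far. Compound 1, `COc1cc(/C=C/C(=O)NCCN2CCCCC2C)cc(OC)c1OC`, gives only a limit of the assay, > 1000 nM; here the limit of > 1000 nM in this assay, at which 1 of the 3 values shown sits, applies. Compound 2, `COc1cc(CCC(=O)NCCn2c(C)cc3ccccc32)cc(OC)c1OC`, gives 214 nM. Compound 3, `Cc1cc(/C=C/C(=O)NCCn2c(C)cc3ccccc32)cc(C)c1F`, gives 3.4 nM, the lower of the two numbers recorded, and its gap to compound 2 lies well beyond the scatter. Compound 4, `Cc1cc(/C=C/C(=O)NCCn2c(C(F)(F)F)cc3ccccc32)cc(C)c1F`, has not yet been measured; it differs from compound 3 by trifluoromethyl in place of methyl on an aromatic carbon. For the measured compounds named here, no pair of measured compounds isolates this change, so its size cannot be read from the data. In this assay the step is expected to be small and toward a weaker inhibitor, a 2.4-fold higher number from compound 3 to compound 4 (0.37 log units; beyond the scatter). Compound 4 is therefore estimated at 8 nM, with a likely range from 2 nM to 40 nM.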

Compound 4, antagonist equilibrium constant: 306 nM
For compound 4 the middle estimate is 38-fold (1.58 log units) below the measured one; measured number outside the range, above it.
By their numbers in this assay, from the lowest: compound 3; then compounds 2 and 4 (each within the scatter of the next). At a limit, above all of these: compound 1.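

In this assay, for the compounds shown here, trifluoromethyl in place of methyl on this aromatic carbon, next to the ring nitrogen, gives a 90-fold higher number from compound 3 to compound 4 (1.95 log units; beyond the scatter) and is the first measured change at this position, where compound 2 and compound 3 both carry methyl. The position therefore responds strongly to what it bears, and this single replacement takes away most of what compound 3 shows. Nothing measured here accounts for the size of this step. Open, going by these compounds, is how hydrogen, chlorine or an ethyl group at this position would read in this assay, and thus whether methyl is unusually favourable or trifluoromethyl unusually poor.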